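Chloromethylbenzyl purines: amino substitution and growth inhibition

This account rests on a few compounds, and the source may have more. Where it says the series, first, only, none or still open, it means among the compounds named here.

Measured in a functional assay on K562 cells (Homo sapiens) for cytotoxicity, read by sulforhodamine B assay, with a stated time of 48 h; on this read-out lower numbers stand for stronger inhibition of growth and higher numbers for weaker inhibition of growth:
compound 1 `ClCc1ccc(Cn2cnc3c(Cl)ncnc32)cc1` gives > 100000 nM, a limit rather than a number.
compound 2 `Nc1nc(Cl)c2ncn(Cc3ccc(CCl)cc3)c2n1` gives > 100000 nM, again a limit.
compound 3 `ClCc1ccccc1Cn1cnc2c(Cl)ncnc21` gives 5120 nM.

Within the data shown here, compound 3 supplies the only number in the set; the two other values sit at the limit of > 100000 nM in this assay, at which 2 of the 3 values shown sit. The difference between the core of compound 1 and the core of compound 3 is not broken down here. The change amino in place of hydrogen on an aromatic carbon yields a step that the two limits leave unreadable from compound 1 to compound 2. Compound 4 `Nc1nc(Cl)c2ncn(Cc3ccccc3CCl)c2n1` carries the same kind of change, (amino in place of hydrogen on an aromatic carbon), with the place described in the same words. Since the measured step cannot be sized, the expectation rests on compound 3 alone at 5120 nM, and the expected step is a 1.2-fold higher number from compound 3 to compound 4 (0.07 log units; within the scatter) in this assay, kept close to no change with wide bounds. Compound 4 is estimated at 6000 nM, between 1500 nM and 40000 nM.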

Compound 4, concentration for total growth inhibition: > 100000 nM
Compound 4: no number, only a limit; the forecaster's own chance of this, stated with the estimate: 25%; at least 16-fold (1.22 log units) between middle value and limit.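

In this assay, amino in place of hydrogen on an aromatic carbon gives an at least 19-fold higher number from compound 3 to compound 4 (1.29 log units; beyond the scatter), so on the core of compound 3 this change weakens growth inhibition. Compound 4 gives > 100000 nM, which is a limit and not a number. The step from compound 1 to compound 2 cannot be read, so whether the change behaves alike on both cores is not shown: the limit of > 100000 nM in this assay, at which 3 of the 4 values shown sit.

Open, as far as these compounds go, is whether a group other than amino at the same carbon, such as methylamino or hydroxyl, would stay near compound 3 at 5120 nM. Also open, from the compounds shown here alone, is how a methoxy group in place of the chloro group would read on the core of compound 3.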